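The source may hold more compounds than are shown below. What is called first, only, known or untested is meant among the compounds shown, and "the series" means these compounds.

Among the compounds with values here, compound 2, `CCCS(=O)(=O)Nc1ccc(F)c(C(=O)c2n[nH]c3ncc(-c4cccc(N(C)C)c4)cc23)c1F`, gives 26% in an assay for binding affinity to dual specificity mitogen-activated protein kinase kinase 4 (Homo sapiens), read by KINOMEscan, tested at 100 nM (on this read-out lower numbers stand for a stronger effect and higher numbers for a weaker effect at the one concentration tested), the higher of the two numbers known here. Compound 1, `CCCS(=O)(=O)Nc1ccc(F)c(C(=O)c2n[nH]c3ncc(-c4cccc(F)c4)cc23)c1F`, gives 8.2% in this assay. Within the data shown here, the one measured step, a number 17.8 percentage points higher from compound 1 to compound 2 (beyond the scatter), shows that exchanging a halogen for an amino substituent on this phenyl ring moved the read-out by a modest amount, beyond the scatter. Compound 3, `CCCS(=O)(=O)Nc1ccc(F)c(C(=O)c2n[nH]c3ncc(-c4ccc(Cl)c(Cl)c4)cc23)c1F`, carries instead (3,4-dichlorophenyl in place of 3-(dimethylamino)phenyl on an aromatic carbon). Among the measured compounds shown here, this change returns the phenyl ring to halogen substitution, which is the pattern of compound 1 rather than compound 2, so the one known step bears on it in reverse; however, no measured compound carries two halogens on this ring, and the size of the return cannot be read off directly. The account therefore expects a step of about a number 14 percentage points lower from compound 2 to compound 3 (beyond the scatter), downward, and estimates for compound 3 a value of 12%, with a range from 4% to 32%.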

Compound 3, a percentage reported as activity, at one concentration (the size of the read-out at that concentration, not a potency): 45%
Beside the measured number, compound 3's estimate is 33 percentage points below it, outside the stated range (above it).
By their numbers in this assay, from the lowest: compound 1; then compound 2; then compound 3.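

Replacing 3-fluorophenyl with 3,4-dichlorophenyl in this assay gives a number 36.8 percentage points higher from compound 1 to compound 3 (beyond the scatter), so halogen substitution on this phenyl ring does not by itself keep the read-out low. Replacing 3-(dimethylamino)phenyl with 3,4-dichlorophenyl gives a number 19 percentage points higher from compound 2 to compound 3 (beyond the scatter), which places the amino-substituted compound 2 between the two halogen-substituted compounds and breaks any simple division of halogen against amino at this position. No measurement among the data shown accounts for these steps.

The compounds shown leave open whether the rise follows from chlorine standing in place of fluorine or from the ring carrying a second halogen. A phenyl ring with a single chlorine and one with two fluorines would separate these two readings, and an unsubstituted phenyl ring would give a plain reference for all three.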